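The source may hold more compounds than are shown below. What is called first, only, known or untested is meant among the compounds shown, and "the series" means these compounds.

Working notes on the series. Compound 1 `C/C(=N\Cc1ccccn1)c1c(O)c2ccccc2oc1=O` gives 22000 nM in an assay on isolated protein for inhibition of myosin-2 (Bos taurus), read by spectrophotometry, with a stated time of 24 min; a lower number here means a stronger inhibitor, a higher number a weaker inhibitor. Compound 2 `CCCCC/N=C(\C)c1c(O)c2ccccc2oc1=O` gives 6700 nM in this assay. Going by the values given here, the one step measured so far is a 3.3-fold lower number from compound 1 to compound 2 (0.52 log units; beyond the scatter), butyl in place of pyridin-2-yl on a saturated chain carbon bound to a double-bonded nitrogen. Among the compounds with values here, compound 2 thus holds the lower of the two numbers, with compound 1 its only neighbour and beyond the scatter from it.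

Compound 3 `C/C(=N\Cc1ccc(C)cc1)c1c(O)c2ccccc2oc1=O` is not yet measured. Its change from compound 2 is 4-methylphenyl in place of butyl on a saturated chain carbon bound to a double-bonded nitrogen. Within the data shown here, the only step that bears on this is a 3.3-fold lower number from compound 1 to compound 2 (0.52 log units; beyond the scatter), which ran the other way: an aromatic ring left, butyl entered, and the number fell. With an aromatic ring entering again, though 4-methylphenyl rather than pyridin-2-yl, the number is expected to move back toward that of compound 1 22000 nM, with the size uncertain. The expected step is a 1.9-fold higher number from compound 2 to compound 3 (0.29 log units; within the scatter). Compound 3 is estimated at 13000 nM, with a range from 5000 nM to 35000 nM.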

Compound 3, half-maximal inhibitory concentration: 7900 nM
The estimate for compound 3 lay 1.6-fold (0.22 log units) above the measured number, and the stated range covers the measured number.
By their numbers in this assay, from the lowest: compounds 2 and 3 (each within the scatter of the next); then compound 1.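

In this assay the step of a 1.2-fold higher number from compound 2 to compound 3 (0.07 log units; within the scatter) shows that this place, on a saturated chain carbon bound to a double-bonded nitrogen, takes 4-methylphenyl and butyl without a difference beyond the scatter, so an aromatic ring as such does not bring the number back toward that of compound 1. The step of a 2.8-fold lower number from compound 1 to compound 3 (0.44 log units; beyond the scatter) then sets pyridin-2-yl apart from 4-methylphenyl as well as from butyl, and of the three groups only pyridin-2-yl, in compound 1, goes with the higher number. Nothing on hand explains this difference.

The compounds shown do not separate the ring nitrogen of pyridin-2-yl from the methyl of 4-methylphenyl, which plain phenyl would help to do. As far as these compounds go, a chain longer than butyl, or one ending in an amine or a carboxylic acid, also remains open at this place.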